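Chloro Substitution on Two Aryl Rings in an Antiproliferative Series

A few compounds are considered here, and "the series" means these few. Any claim that something is new, unique, unknown or untested is made for them only; others in the source may bear on it.

Compound 1, `O=[N+]([O-])c1cc(C(F)(F)F)cc([N+](=O)[O-])c1Oc1ccccc1/C=N/OCc1ccccc1Cl`, in a functional assay on MCF7 cells (Homo sapiens) for antiproliferative activity, read by MTT assay, with a stated time of 48 h (on this read-out lower numbers stand for stronger inhibition and higher numbers for weaker inhibition), compound 1 gives 1100 nM.
Compound 2, `O=[N+]([O-])c1cc(C(F)(F)F)cc([N+](=O)[O-])c1Oc1ccccc1/C=N/OCc1ccc(Cl)cc1Cl`, in this assay compound 2 gives 940 nM.
Compound 3, `O=[N+]([O-])c1cc(C(F)(F)F)cc([N+](=O)[O-])c1Oc1ccc(Cl)cc1/C=N\OCc1ccccc1`, in this assay compound 3 gives 1220 nM.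

Compound 2 differs from compound 1 by chloro in place of hydrogen on an aromatic carbon, and this gives a 1.2-fold lower number from compound 1 to compound 2 (0.07 log units; within the scatter). Compound 3 shares its atoms with compound 1 but joins them differently; the difference between the two cores is not broken down here, and the values of compound 1 and compound 3 lie within the scatter of each other.

Compound 4, `O=[N+]([O-])c1cc(C(F)(F)F)cc([N+](=O)[O-])c1Oc1c(Cl)cc(Cl)cc1/C=N\OCc1ccccc1`, has not been measured. It differs from compound 3 by chloro in place of hydrogen on an aromatic carbon. The surroundings are not identical: in compound 2 the new chloro sits meta to a chloro group and para to a large group, whereas in compound 4 it sits ortho to a large group, meta to a chloro group and meta to a large group, so this is the same kind of change rather than the same change. For the measured compounds named here, only one earlier step is available, and it stayed within the scatter.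

Compound 4 is therefore expected to show a 1.2-fold lower number from compound 3 to compound 4 (0.09 log units; within the scatter), resting on a 1.2-fold lower number from compound 1 to compound 2 (0.07 log units; within the scatter). In this assay compound 4 is estimated at 1000 nM, with a likely range from 500 nM to 2100 nM.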

Compound 4, half-maximal inhibitory concentration: 1210 nM
Estimate against measurement, compound 4: 1.2-fold (0.08 log units) below; the measured number falls inside the stated range.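

In this assay, chloro in place of hydrogen on an aromatic carbon gives a 1.0-fold lower number from compound 3 to compound 4 (0.00 log units; within the scatter), so this step, like the earlier one, stays within the scatter. Set side by side, the two steps do not differ readably: the same change on two cores in this assay, a 1.2-fold lower number (0.07 log units; within the scatter) from compound 1 to compound 2 and a 1.0-fold lower number (0.00 log units; within the scatter) from compound 3 to compound 4, 1.2-fold (0.06 log units) apart, within the scatter of two such steps. For the compounds shown here, this shows that the change left the number within the scatter on both cores, but with only two steps, and with different surroundings around the new chloro in each, it does not show that the change would behave the same way at other places or on other cores.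

The compounds shown leave open whether a different group at these places, such as a methoxy group, an amine or a carboxylic acid, would shift the number beyond the scatter.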